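Trifluoromethoxy for Trifluoromethyl on a Weakly Cytotoxic Amide

The source may hold more compounds than are shown below. What is called first, only, known or untested is meant among the compounds shown, and "the series" means these compounds.

Compound 2 `Cc1cc(=O)n(-c2ccccc2C(F)(F)F)nc1C(=O)Nc1ccc(Oc2ncnc3sccc23)cc1` is one of two measured members of this set. In a functional assay on HepG2 cells (Homo sapiens) for cytotoxicity, read by MTT assay, with a stated time of 72 h (a lower number here means a stronger inhibitor, a higher number a weaker inhibitor), compound 2 gives only a limit of the assay, > 40000 nM. Its measured partner, compound 1 `Cc1cc(=O)n(-c2ccccc2C(F)(F)F)nc1C(=O)Nc1ccc(Oc2ncnc3ccsc23)cc1`, differs on the oxygen on an aromatic ring, and in this assay compound 1 gives 9230 nM. Going by the values given here, the single measured step is an at least 4.3-fold higher number from compound 1 to compound 2 (0.63 log units; beyond the scatter). That step ends at the limit of > 40000 nM in this assay, at which 1 of the 2 values shown sits, which is where compound 2 stands.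

Compound 3 `Cc1cc(=O)n(-c2ccccc2OC(F)(F)F)nc1C(=O)Nc1ccc(Oc2ncnc3sccc23)cc1` is not yet measured. It differs from compound 2 by trifluoromethoxy in place of trifluoromethyl on an aromatic carbon, a trifluoromethoxy in place of a trifluoromethyl on an aromatic carbon of a six-membered aromatic ring of carbon only, ortho to a large group. Among the compounds with values here, no measured step touches that position, so the one measured step gives no guidance on direction or size. The expected step is a step that the limit leaves unreadable from compound 2 to compound 3, none beyond the scatter. Compound 3 is therefore estimated at 60000 nM, in a range from 20000 nM to 200000 nM.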

Compound 3, half-maximal inhibitory concentration: 14400 nM
For compound 3 the middle estimate is 4.2-fold (0.62 log units) above the measured one, outside the stated range (below it).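

In this assay, the change from 2-(trifluoromethyl)phenyl to 2-(trifluoromethoxy)phenyl gives an at least 2.7-fold lower number from compound 2 to compound 3 (0.44 log units; beyond the scatter), so the position ortho to a large group on this carbon-only ring also bears on the read-out. The earlier step concerned only the group on the oxygen on an aromatic ring, whereas here the whole difference lies in the trifluoromethoxy that replaces the trifluoromethyl. Compound 2 sits at a limit of the assay, so this result fixes the direction of the change and a minimum for its size, but not the size itself: the limit of > 40000 nM in this assay, at which 1 of the 3 values shown sits.

Going by these compounds, it remains open whether a methoxy, a chlorine or an amine at this position would give a similar number. On these data alone, it is equally open whether the same exchange would move the number in the same direction on the core of compound 1.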